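Swapping 2-chlorophenyl for 4-fluorophenyl on a saturated ring carbon

This account rests on a few compounds, and the source may have more. Where it says the series, first, only, none or still open, it means among the compounds named here.

Compound 2 `N#CC1=C(N)OC(c2c[nH]c3ccccc23)=C(C#N)C1c1ccccc1Cl` stands at the lower of the two numbers shown so far. In a functional assay, tested at 400 ug/mL (on this read-out higher numbers stand for a stronger effect at the one concentration tested and lower numbers for a weaker effect), compound 2 gives 21.4%. Among the compounds with values here, its only neighbour is compound 1 `COc1ccc(C2C(C#N)=C(N)OC(c3c[nH]c4ccccc34)=C2C#N)cc1`, which in this assay gives 28.7%; the single measured step, a number 7.3 percentage points lower from compound 1 to compound 2 (within the scatter), lies within the scatter, so the two compounds cannot be told apart on this read-out.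

Compound 3 `N#CC1=C(N)OC(c2c[nH]c3ccccc23)=C(C#N)C1c1ccc(F)cc1` differs from compound 2 in one place: 4-fluorophenyl in place of 2-chlorophenyl on a saturated ring carbon.

Within the data shown here, the only measured step that bears on this change is the one in which 2-chlorophenyl replaced 4-methoxyphenyl on the same saturated ring carbon, and it came out as a number 7.3 percentage points lower from compound 1 to compound 2 (within the scatter), within the scatter. The present change is another exchange of the group on that saturated ring carbon, and nothing measured shows such an exchange moving the read-out beyond the scatter. Compound 3 is therefore expected to sit close to compound 2, with an expected step of a number 2.6 percentage points higher from compound 2 to compound 3 (within the scatter). The estimate for compound 3 is 24%, expected to fall between 12% and 36%.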

Compound 3, a percentage reported as activity, at one concentration (the size of the read-out at that concentration, not a potency): 26.7%
Beside the measured number, compound 3's estimate is 2.7 percentage points below it; the range from low to high includes it.
By their numbers in this assay, from the lowest: compounds 2, 3 and 1 (each within the scatter of the next).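

With compound 3, the saturated ring carbon has now carried 4-methoxyphenyl, 2-chlorophenyl and 4-fluorophenyl, and in this assay both new steps stay within the scatter: the exchange of 2-chlorophenyl for 4-fluorophenyl gives (a number 5.3 percentage points higher from compound 2 to compound 3 (within the scatter)), and the exchange of methoxy for fluoro on an aromatic carbon gives (a number 2 percentage points lower from compound 1 to compound 3 (within the scatter)). Within the data shown here, the first of these changes both the halogen and the name of the substituted phenyl group, yet the read-out does not separate compound 2 from compound 3, so this assay so far tolerates all three substituted phenyl groups at this position without a distinguishable change. Nothing available on these compounds accounts for how closely they read.

On these data alone, all three compounds carry a phenyl ring with a single substituent here, so it remains open whether a larger change, such as a cyclohexyl group, a pyridyl ring or a phenyl ring bearing a carboxylic acid, would move the read-out beyond the scatter. The 1H-indol-3-yl group, the amino group and the two cyano groups are also the same throughout, which leaves their contribution to the read-out open.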